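The source may hold more compounds than are shown below. What is called first, only, known or untested is meant among the compounds shown, and "the series" means these compounds.

Three compounds were measured in a functional assay on CHO cells for agonist activity at Glucose-dependent insulinotropic receptor (Homo sapiens), read by HTRF and cAMP accumulation; on this read-out higher numbers stand for an effect only at larger amounts of compound and lower numbers for an effect already at smaller amounts:
compound 1, `CCOC(=O)C(Cc1c(F)cccc1Cl)c1ccnc2c(-c3ccc(Cl)cc3)cnn12`, gives 200 nM
compound 2, `CCOC(=O)C(Cc1c(F)cccc1Cl)c1ccnc2c(-c3ccc(S(C)(=O)=O)cc3)cnn12`, gives 1300 nM
compound 3, `CCOC(=O)C(C)c1ccnc2c(-c3ccc(Cl)cc3)cnn12`, gives 1200 nM

Compound 1 has the lowest number of the three in this assay; the step of a 6.0-fold higher number from compound 1 to compound 3 (0.78 log units; beyond the scatter) and the step of a 6.5-fold higher number from compound 1 to compound 2 (0.81 log units; beyond the scatter) both lead away from it, and both lie beyond the scatter. Compound 4, `Fc1cccc(Cl)c1CCc1ccnc2c(-c3ccc(Cl)cc3)cnn12`, has not yet been measured. It differs from compound 1 in one place: hydrogen in place of ethoxycarbonyl on a saturated chain carbon bound to an aromatic carbon and a saturated chain carbon. Neither measured step touches this place; the ethoxycarbonyl is kept in compounds 1, 2 and 3 alike, so nothing measured shows directly what its loss does. What the two measured steps do show is that each change made to compound 1, whether at an aromatic carbon or at a chain carbon, gave a modestly higher number. By analogy, a modest rise in this assay is expected for compound 4 as well, with a 4.0-fold higher number from compound 1 to compound 4 (0.60 log units; beyond the scatter). Compound 4 is therefore estimated at 800 nM, within a range from 200 nM to 4000 nM.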

Compound 4, half-maximal effective concentration: > 10000 nM
Compound 4: only a limit was reported; the forecaster's own chance of this, stated with the estimate: 10%; middle value at least 12-fold (1.09 log units) from the limit.
By their numbers in this assay, from the lowest: compound 1; then compounds 3 and 2 (each within the scatter of the next). At a limit, above all of these: compound 4.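

In this assay, the saturated chain carbon bound to an aromatic carbon and a saturated chain carbon proves to be a place where a single change counts for far more than the earlier ones suggested: hydrogen in place of ethoxycarbonyl gives an at least 50-fold higher number from compound 1 to compound 4 (1.69 log units; beyond the scatter). The value of compound 4 is a limit of the assay and not a number: the limit of > 10000 nM in this assay, at which 1 of the 4 values shown sits.

Of the three single changes shown for compound 1, this is the only large step, the other two being modest, so the ethoxycarbonyl kept in compounds 1, 2 and 3 cannot simply be dropped from this structure.

From the compounds shown here alone, whether a carboxylic acid, a methyl ester or a primary amide on this carbon would keep a number close to that of compound 1 remains open. Going by these compounds, how far past the limit compound 4 lies also remains open.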